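Compound 3 to compound 4: a chain change

A few compounds are considered here, and "the series" means these few. Any claim that something is new, unique, unknown or untested is made for them only; others in the source may bear on it.

Of the compounds shown here, three have been measured in an ADME assay (liver) for metabolic stability, with Liver microsome (Homo sapiens) as the target, read by LC-MS, using microsomes, tested at 1 uM; a lower number here means that the compound disappears faster, a higher number that the compound lasts longer. Compound 1 `CCN(CC)CCC/N=C(/N=c1\ccn(CCCN(CC)CC)c2cc(Cl)ccc12)c1cccnc1` reads > 1 h, which is a limit of the assay and not a number. Compound 2 `C/C(=N/c1ccnc2cc(Cl)ccc12)NCCCCN1CCCCC1` reads > 1 h, again a limit of the assay. For the measured compounds named here, compound 3 `CC(C)/C(=N/c1ccnc2cc(Cl)ccc12)NCCCCN1CCCCC1` gives 0.483 h, the only actual number among the three.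

Going by the values given here, the one measured step, isopropyl in place of methyl on a carbon with a double bond to nitrogen, is an at least 2.0-fold lower number from compound 2 to compound 3 (0.31 log units; beyond the scatter). Its size is only a floor, set by the limit of > 1 h in this assay, at which 2 of the 3 values shown sit.

The next compound is compound 4 `CC(C)/C(=N/c1ccnc2cc(Cl)ccc12)NCCCN1CCCCC1`, which differs from compound 3 as follows: piperidin-1-yl in place of (piperidin-1-yl)methyl on a saturated chain carbon, three bonds along the chain from an amine nitrogen. The change is piperidin-1-yl in place of (piperidin-1-yl)methyl, on a saturated chain carbon, three bonds along the chain from an amine nitrogen. Among the compounds with values here, the measured step lies at another place in the structure, so it gives no size to carry over, and no measured step alters this chain. No change beyond the scatter is therefore expected in this assay, and compound 3 at 0.483 h serves as the starting point. The expected change is a 1.1-fold higher number from compound 3 to compound 4 (0.06 log units; within the scatter). For compound 4 the estimated half-life is 0.55 h, with an expected range from 0.28 h to 1 h.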

Compound 4, half-life: 0.483 h
For compound 4 the middle estimate is 1.1-fold (0.06 log units) above the measured one; the range from low to high includes it.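

In this assay, exchanging (piperidin-1-yl)methyl for piperidin-1-yl on a saturated chain carbon, three bonds along the chain from an amine nitrogen, gives no change at the digits printed from compound 3 to compound 4 (within the scatter). With isopropyl held in place on the carbon with a double bond to nitrogen, the half-life therefore does not tell the longer chain of compound 3 from the shorter chain of compound 4. This is also the first step with an actual number at both ends, so its size can be read directly, whereas the earlier step gives only a floor: the limit of > 1 h in this assay, at which 2 of the 4 values shown sit.

The compounds shown leave open whether a still shorter chain or a longer one would read the same, and whether the result would hold with a morpholine or a diethylamino group in place of the piperidine. They also leave open whether the same chain change would read alike with methyl instead of isopropyl on the carbon with a double bond to nitrogen.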